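The source may report more compounds than this note shows. Statements on the series, on what has been measured and on what is new or still open speak of the compounds shown alone.

The study set out from compound 1 `CC(=O)c1ccc2c(c1)N(C1=CCCC1=O)CC(C)(C)S2` and compound 2 `CC1CN(C2=CCCC2=O)c2cc(C(F)(F)F)ccc2S1`, both of which had been measured in a functional assay on aorta (Rattus norvegicus, strain Wistar), in the presence of a further agent that is not named here; a higher number here means a larger maximal response, a lower number a smaller maximal response. In this assay compound 1 gave 77%, and compound 2 gave 63%. Of the two numbers in hand, compound 1 thus stood highest, with compound 2 the only other point and its value lower by more than the usual scatter. For the measured compounds named here, no step between the two measured compounds was worked out, since they differ in more than one place.

The next compound, compound 3 `CC1(C)CN(C2=CCCC2=O)c2ccccc2S1`, returned to the core of compound 1 and changed one thing only: hydrogen in place of acetyl on an aromatic carbon. Going by the values given here, with no measured pair covering this particular change, the size of its effect had to be guessed from the two values alone. A small step downward in this assay was expected, one that might not clearly exceed the scatter, as the expected step of a number 9 percentage points lower from compound 1 to compound 3 (within the scatter) shows. The value of compound 3 in this assay was accordingly estimated at 68%, within a range from 50% to 85%.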

Compound 3, largest response reached (Emax), in percent of the reference or control that the assay uses: 61%
Compound 3: middle estimate off by 7 percentage points, on the high side; the measured number falls inside the stated range.
By their numbers in this assay, from the lowest: compounds 3 and 2 (each within the scatter of the next); then compound 1.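

Replacing acetyl with hydrogen on the aromatic carbon, with the rest of the core of compound 1 unchanged, gave a number 16 percentage points lower from compound 1 to compound 3 (beyond the scatter) in this assay and so showed that the maximal response depends on what this position carries. For the compounds shown here, the earlier gap between compound 1 and compound 2 could not be tied to any single place, as those two compounds differ in more than one; this step is the first that can be assigned to one change, the loss of acetyl. Nothing measured here accounts for the size or direction of this step.

As far as these compounds go, what remains open is whether acetyl itself matters at this aromatic carbon or whether other groups would serve equally well, and a nitrile, a methyl ester, an amine or a carboxylic acid placed there on the same core would begin to separate these possibilities. Going by these compounds alone, a single pair also leaves open whether the same replacement would lower the response to a similar extent on a core carrying a different substitution, such as the single methyl group of compound 2.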